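Adding a second methoxy to compound 3

The compounds below may be only part of what the source reports. "The series", "measured", "known", "first", "only" and "open" are said of these compounds alone.

Measured so far in a functional assay on HeLa cells (Homo sapiens) for cytotoxicity, read by sulforhodamine B assay; a higher number here means a weaker inhibitor, a lower number a stronger inhibitor:
Compound 1 `COc1ccc(S(=O)(=O)NC(C2=CC(=O)c3c(O)ccc(O)c3C2=O)C(C)C)c(OC)c1` gives 2750 nM
Compound 2 `Cc1ccccc1S(=O)(=O)NC(C)C1=CC(=O)c2c(O)ccc(O)c2C1=O` gives 4490 nM
Compound 3 `COc1ccc(S(=O)(=O)NC(C)C2=CC(=O)c3c(O)ccc(O)c3C2=O)cc1` gives 3760 nM

These three values lie within the usual scatter of one another, so compound 3 at 3760 nM holds no clear rank among them. The next compound to test is compound 4 `COc1ccc(S(=O)(=O)NC(C)C2=CC(=O)c3c(O)ccc(O)c3C2=O)c(OC)c1`, made from compound 3 by one change: methoxy in place of hydrogen on an aromatic carbon. Methoxy replaces hydrogen on an aromatic carbon, turning 4-methoxyphenyl into 2,4-dimethoxyphenyl.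

Among the compounds with values here, only one measured step changes this same aromatic group with nothing else altered: a 1.2-fold lower number from compound 2 to compound 3 (0.08 log units; within the scatter). That step stays within the scatter. Compound 1 also carries 2,4-dimethoxyphenyl and gives 2750 nM, but it differs from compound 4 elsewhere as well, so it offers only a loose guide. Together these results give no reason to expect a shift beyond the scatter in this assay, and they set no firm direction. The expected step is small, at a 1.2-fold lower number from compound 3 to compound 4 (0.08 log units; within the scatter). Compound 4 is estimated at 3100 nM, with an expected range from 1600 nM to 6000 nM.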

Compound 4, half-maximal inhibitory concentration: 19500 nM
For compound 4 the middle estimate is 6.3-fold (0.80 log units) below the measured one; the measured number lies above the stated range.
By their numbers in this assay, from the lowest: compounds 1, 3 and 2 (each within the scatter of the next); then compound 4.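

In this assay, within the data shown here, the aromatic carbon ortho to a large group proves sensitive: methoxy in place of hydrogen there gives a 5.2-fold higher number from compound 3 to compound 4 (0.71 log units; beyond the scatter) and so weakens the compound, the first change to this aromatic group that goes beyond the scatter. Replacing 2-methylphenyl with 2,4-dimethoxyphenyl points the same way, giving a 4.3-fold higher number from compound 2 to compound 4 (0.64 log units; beyond the scatter) as the result of that swap on the sulfonyl sulfur. The 2,4-dimethoxyphenyl group does not set the number on its own, since methyl in place of isopropyl on the saturated chain carbon gives a 7.1-fold higher number from compound 1 to compound 4 (0.85 log units; beyond the scatter) even though both compounds carry this aromatic group. No measurement available here explains why the added methoxy weakens compound 4.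

Still open, on these data alone, is how other groups on the same aromatic carbon would behave, such as a single fluorine atom, a hydroxyl or a longer ethoxy, and whether the outcome follows the size of the group. Also open, as far as these compounds go, is how isopropyl on the chain carbon would behave alongside the 4-methoxyphenyl group of compound 3, a pairing that would show whether the chain and the aromatic group act independently.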